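The source may report more compounds than this note shows. Statements on the series, on what has been measured and on what is new or still open speak of the compounds shown alone.

Compound 3 `O=C(CN1CCC(c2cccc[n+]2[O-])CC1)NC1CCCCC1` gives 58% in a functional assay on HEK293 cells for agonist activity at D(4) dopamine receptor (Homo sapiens), read by FLIPR (a lower number here means a smaller maximal response, a higher number a larger maximal response), the second highest of the three numbers measured. Compound 1 `Cc1cccc(NC(=O)CN2CCC(c3nccs3)CC2)c1` gives 62% in this assay, within the scatter of compound 3, while compound 2 `Cc1cccc(NC(=O)CN2CCC(c3cccc(F)c3)CC2)c1` gives 40%, beyond the scatter below compound 3. For the measured compounds named here, the one measured step, a number 22 percentage points lower from compound 1 to compound 2 (beyond the scatter), concerns the group on the saturated ring carbon, not the amide nitrogen. Compound 4 `CSc1cccc(NC(=O)CN2CCC(c3cccc[n+]3[O-])CC2)c1` differs from compound 3 by 3-(methylsulfanyl)phenyl in place of cyclohexyl on an amide-type nitrogen. Going by the values given here, no measured step touches the amide nitrogen; compounds 1 and 2 carry an aromatic group there and bracket compound 3, so nothing beyond the scatter is anticipated. Compound 4 is therefore expected to give about 55% in this assay, between 35% and 75%. This expectation means a number 3 percentage points lower from compound 3 to compound 4 (within the scatter).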

Compound 4, largest response reached (reported as efficacy), in percent of the reference or control that the assay uses: 56%
Compound 4: middle estimate off by 1 percentage points, on the low side; measured number inside the range.
By their numbers in this assay, from the lowest: compound 2; then compounds 4, 3 and 1 (each within the scatter of the next).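

In this assay, 3-(methylsulfanyl)phenyl in place of cyclohexyl on the amide nitrogen gives a number 2 percentage points lower from compound 3 to compound 4 (within the scatter) and so, on this core, does not separate the aromatic ring from the saturated carbon ring. For the compounds shown here, the earlier step covered only the saturated ring carbon, so this is the only reading at the amide nitrogen. No measured property bears on this result.

Still open, going by these compounds, is whether a much smaller group on the amide nitrogen, such as methyl, or a longer chain ending in an amine keeps the response. On these data alone, whether this insensitivity carries over to the cores of compound 1 and compound 2 is also open.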